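Amide substituent variation on the shared core: acid retention

The source may hold more compounds than are shown below. What is called first, only, known or untested is meant among the compounds shown, and "the series" means these compounds.

Of the compounds shown here, three have been measured in an assay on cells for agonist activity at vitamin D3 receptor (Homo sapiens), with a stated time of 96 h; on this read-out higher numbers stand for an effect only at larger amounts of compound and lower numbers for an effect already at smaller amounts. Compound 1 `CCn1c(C(=O)NCC#N)ccc1C(CC)(CC)c1ccc(OCCC(O)(CC)CC)c(C)c1` gives 1080 nM. Compound 2 `CCn1c(C(=O)Nc2cccc(C(F)(F)F)c2)ccc1C(CC)(CC)c1ccc(OCCC(O)(CC)CC)c(C)c1` gives 5900 nM. Among the compounds with values here, compound 3 `CCn1c(C(=O)NC(CC(=O)O)C(=O)OC)ccc1C(CC)(CC)c1ccc(OCCC(O)(CC)CC)c(C)c1` gives 26 nM, the lowest number of the three; its separation from compound 1 is a 42-fold lower number from compound 1 to compound 3 (1.62 log units; beyond the scatter) and from compound 2 it is a 230-fold lower number from compound 2 to compound 3 (2.36 log units; beyond the scatter), both beyond the scatter, so compound 3 is the most potent compound measured so far.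

Compound 4 `CCn1c(C(=O)NC(C)C(=O)O)ccc1C(CC)(CC)c1ccc(OCCC(O)(CC)CC)c(C)c1` is the next step from compound 3. The change is a group of 5 heavy atoms (3 carbon, 2 oxygen; no ring) in place of a group of 9 heavy atoms (5 carbon, 4 oxygen; no ring), on an amide-type nitrogen. The carboxylic acid and the amide hydrogen are kept, while the methyl ester and one chain carbon are lost.

The bearing steps are those leading to compound 3. The step of a 42-fold lower number from compound 1 to compound 3 (1.62 log units; beyond the scatter) shows that a large gain accompanied the introduction of the acid-bearing group, and a 230-fold lower number from compound 2 to compound 3 (2.36 log units; beyond the scatter) points the same way. Compound 4 keeps the acid but carries a shorter group, so part of the gain is expected to be retained and part may be lost; a modest rise in the number in this assay is therefore expected, a 2.7-fold higher number from compound 3 to compound 4 (0.43 log units; beyond the scatter). Compound 4 is estimated to give 70 nM in this assay, with a range of 18 nM to 280 nM.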

Compound 4, half-maximal effective concentration: 66 nM
The estimate for compound 4 lay 1.1-fold (0.03 log units) above the measured number, within the range that was stated.
By their numbers in this assay, from the lowest: compound 3; then compound 4; then compound 1; then compound 2.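

Notes on the amide position: in this assay, the 1-carboxyethyl group on the amide-type nitrogen stays far ahead of both groups without a carboxylic acid (a 16-fold lower number from compound 1 to compound 4 (1.21 log units; beyond the scatter); an 89-fold lower number from compound 2 to compound 4 (1.95 log units; beyond the scatter)), so most of the large gain seen with compound 3 persists without the methyl ester and with a shorter group. Going from the group of 9 heavy atoms to 1-carboxyethyl costs only a modest step beyond the scatter (a 2.5-fold higher number from compound 3 to compound 4 (0.40 log units; beyond the scatter)), which is small beside the two large steps and shows that this position tolerates the loss of the ester and one chain carbon with limited change in the number. No measured property is available to explain these differences.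

The step to compound 4 removes the methyl ester and the chain carbon together, so their separate contributions cannot be read from these compounds. Also open, going by these compounds, is whether the carboxylic acid itself is needed, which a methyl ester or primary amide in its place on the 1-carboxyethyl group would address, and how an amine or a longer chain ending in a carboxylic acid would stand at this position.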